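A few compounds are considered here, and "the series" means these few. Any claim that something is new, unique, unknown or untested is made for them only; others in the source may bear on it.

Three thiosemicarbazones built on a shared core have been examined in a functional assay on T98G cells (Homo sapiens) for cytotoxicity, read by MTT assay, with a stated time of 48 h; a higher number here means a weaker inhibitor, a lower number a stronger inhibitor. Compound 1 `C/C(=N/NC(=S)Nc1ccccc1F)c1ccccn1` gives 3.1 nM in this assay. Compound 2 `C/C(=N/NC(=S)Nc1ccccc1)c1ccccn1` gives 6.81 nM. Compound 3 `C/C(=N\NC(=S)Nc1ccccc1)c1ccccn1` gives 6.81 nM. Compound 2 and compound 3 differ only as described by the two compounds have the same atoms and bonds and differ only in configuration as drawn: 1 of 1 stereo elements differ; a double bond is drawn Z in compound 2 and E in compound 3, and their readings agree: no change at the digits printed from compound 2 to compound 3 (within the scatter), which is consistent with the fact that compounds 2 and 3 differ only in the configuration as drawn. Between compound 2 and compound 1 the change is fluoro in place of hydrogen on an aromatic carbon, and it produces a 2.2-fold lower number from compound 2 to compound 1 (0.34 log units; beyond the scatter), a modest step but one that lies beyond the usual scatter.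

Compound 4 `C/C(=N\NC(=S)Nc1ccc(F)cc1)c1ccccn1` has not yet been measured in this assay. It differs from compound 3 by fluoro in place of hydrogen on an aromatic carbon. Going by the values given here, this is the same kind of change as the one made from compound 2 to compound 1, but not the same: in compound 1 the fluorine sits ortho to a large group, whereas in compound 4 it sits para to a large group. Among the compounds with values here, the one measured step of this kind, a 2.2-fold lower number from compound 2 to compound 1 (0.34 log units; beyond the scatter), is the only guide available, and the place of the fluoro differs from it. The account expects a step from compound 3 to compound 4 of a 1.5-fold lower number from compound 3 to compound 4 (0.18 log units; within the scatter), of a size comparable to or smaller than that earlier one. On that basis compound 4 is expected to give about 4.5 nM in this assay, with a plausible range from 2 nM to 11 nM.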

Compound 4, half-maximal inhibitory concentration: 17 nM
For compound 4 the middle estimate is 3.8-fold (0.58 log units) below the measured one; measured number outside the range, above it.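

In this assay the same exchange of hydrogen for fluoro now gives a 2.5-fold higher number from compound 3 to compound 4 (0.40 log units; beyond the scatter), which runs opposite to the earlier step and shows that the change does not carry over between these two cores as a fixed shift: the same change on two cores in this assay, a 2.2-fold lower number (0.34 log units; beyond the scatter) from compound 2 to compound 1 and a 2.5-fold higher number (0.40 log units; beyond the scatter) from compound 3 to compound 4, 5.5-fold (0.74 log units) apart, beyond the scatter of two such steps Even the sign of the step cannot be assumed from one core to the other among these compounds, although the unsubstituted starting points themselves read alike, with no change at the digits printed from compound 2 to compound 3 (within the scatter). What this does not show is whether the drawn configuration of the double bond or the place of the fluoro accounts for the gap, as the fluoro is para to a large group in compound 4 and in another place in compound 1, so the two steps differ in both respects at once and the data cannot separate them.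

The compounds shown leave open how fluoro reads at one and the same place on both cores, which is the comparison that would pull these two differences apart. They also leave open whether chloro, methoxy or an amine at the place of the fluoro in compound 4 would follow the rise seen there or the fall seen in compound 1.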